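Bromine on the anilino ring of a quinazoline thioacetamide

This account rests on a few compounds, and the source may have more. Where it says the series, first, only, none or still open, it means among the compounds named here.

Measured so far, in a functional assay on MDA-MB-231 cells (Homo sapiens) for inhibition, read by MTT assay, with a stated time of 72 h; on this read-out higher numbers stand for weaker inhibition and lower numbers for stronger inhibition:
- compound 1 `C=CC(=O)Nc1cccc(NC(=O)CSc2nc(Nc3ccccc3)c3ccccc3n2)c1` gives 10200 nM
- compound 2 `O=C(CSc1nc(Nc2ccccc2)c2ccccc2n1)Nc1ccc(Br)cc1` gives 11500 nM
- compound 3 `O=C(CSc1nc(Nc2ccccc2)c2ccccc2n1)Nc1ccc(F)c(Cl)c1` gives 21600 nM

Compound 1 has the lowest number of the three, although compound 2 sits within the scatter of it; only compound 3 is apart, by a 2.1-fold higher number from compound 1 to compound 3 (0.33 log units; beyond the scatter). The step of a 1.1-fold higher number from compound 1 to compound 2 (0.05 log units; within the scatter) and the step of a 1.9-fold higher number from compound 2 to compound 3 (0.27 log units; within the scatter) both stay within the scatter. All three of these steps alter the amide aryl group; none touches the anilino ring.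

Compound 4 `C=CC(=O)Nc1cccc(NC(=O)CSc2nc(Nc3cccc(Br)c3)c3ccccc3n2)c1` differs from compound 1 by bromo in place of hydrogen on an aromatic carbon. Within the data shown here, no measured step bears on this position, so the estimate rests on compound 1 alone and on the small size of every step seen so far. The step of a 1.0-fold lower number from compound 1 to compound 4 (0.01 log units; within the scatter) is therefore expected to remain within the scatter, in no particular direction. Compound 4 is estimated at 10000 nM, within a range from 4000 nM to 25000 nM.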

Compound 4, half-maximal inhibitory concentration: 19400 nM
For compound 4 the middle estimate is 1.9-fold (0.29 log units) below the measured one; the measured number falls inside the stated range.
By their numbers in this assay, from the lowest: compounds 1, 2, 4 and 3 (each within the scatter of the next, the first and the last beyond it).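

Among these compounds, the anilino ring, untouched by the earlier steps, is now probed for the first time: in this assay, bromo in place of hydrogen on an aromatic carbon, meta to a large group, gives a 1.9-fold higher number from compound 1 to compound 4 (0.28 log units; within the scatter) and so does not separate the two compounds. A single bromine at this position therefore leaves the read-out within the scatter of the unsubstituted ring. Nothing available speaks to the reason for this result.

On these data alone, it remains open how a methoxy group, an amine or a carboxylic acid would read at this position. Also open, as far as these compounds go, is whether bromo here would read the same alongside the 4-bromophenyl amide of compound 2.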